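Cyano for isopropyl on the benzamide of compound 3

The source may report more compounds than this note shows. Statements on the series, on what has been measured and on what is new or still open speak of the compounds shown alone.

Compound 1 `O=C(c1ccc(Oc2ccccc2)cc1)N1CCC(n2cncc2-c2ccc(OS(=O)(=O)c3cccc4cnccc34)cc2)CC1` gives 187 nM in an assay on HEK293 cells for antagonist activity at P2X purinoceptor 7 (Homo sapiens), read by fluorescence, with a stated time of 2 h; a higher number here means a weaker inhibitor, a lower number a stronger inhibitor.
Compound 2 `O=C(c1ccc([N+](=O)[O-])cc1)N1CCC(n2cncc2-c2ccc(OS(=O)(=O)c3cccc4cnccc34)cc2)CC1` gives 1.49 nM in this assay.
Compound 3 `CC(C)c1ccc(C(=O)N2CCC(n3cncc3-c3ccc(OS(=O)(=O)c4cccc5cnccc45)cc3)CC2)cc1` gives 55 nM in this assay.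

Compound 3 holds the second highest of the three numbers, with compound 1 nearest (a 3.4-fold lower number from compound 1 to compound 3 (0.53 log units; beyond the scatter)) and compound 2 furthest (a 37-fold higher number from compound 2 to compound 3 (1.57 log units; beyond the scatter)). Compound 4 `N#Cc1ccc(C(=O)N2CCC(n3cncc3-c3ccc(OS(=O)(=O)c4cccc5cnccc45)cc3)CC2)cc1` is not yet measured; it differs from compound 3 by cyano in place of isopropyl on an aromatic carbon. Within the data shown here, the only step that removes the isopropyl is the reverse of a 37-fold higher number from compound 2 to compound 3 (1.57 log units; beyond the scatter), a large move, so a large lower number is expected in this assay, though the nitro of compound 2 is not the cyano of compound 4. Compound 4 is therefore expected at 6 nM, between 1.5 nM and 25 nM, a step of a 9.2-fold lower number from compound 3 to compound 4 (0.96 log units; beyond the scatter).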

Compound 4, half-maximal inhibitory concentration: 269 nM
The estimate for compound 4 lay 45-fold (1.65 log units) below the measured number, outside the stated range (above it).
By their numbers in this assay, from the lowest: compound 2; then compound 3; then compounds 1 and 4 (each within the scatter of the next).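

In this assay, cyano does not reproduce what nitro does on this aromatic carbon, para to a large group: the exchange gives a 180-fold higher number from compound 2 to compound 4 (2.26 log units; beyond the scatter). The cyano group also gives a 4.9-fold higher number from compound 3 to compound 4 (0.69 log units; beyond the scatter) against isopropyl, and a 1.4-fold higher number from compound 1 to compound 4 (0.16 log units; within the scatter) against phenoxy. Among the four groups shown, only nitro therefore gives a number in the low range, and nothing available here explains why the nitro and cyano groups part so widely. The compounds shown leave open whether an amine, a carboxylic acid or a sulfonamide on this aromatic carbon would give a number as low as that of compound 2.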